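A few compounds are considered here, and "the series" means these few. Any claim that something is new, unique, unknown or untested is made for them only; others in the source may bear on it.

The shared core of this series carries an aryl group on a saturated ring carbon of the five-membered ring. Compound 1 `CCOC(=O)C12C(=O)OCC=C1COC2c1ccc(F)cc1` bears a 4-fluorophenyl there. In a functional assay on A549 cells (Homo sapiens) for cytotoxicity, read by MTT assay (on this read-out higher numbers stand for weaker inhibition and lower numbers for stronger inhibition), compound 1 gives > 1000000 nM, which is a limit of the assay and not a number. Compound 2 `CCOC(=O)C12C(=O)OCC=C1COC2c1ccc(N(C)C)cc1` carries dimethylamino in place of fluoro on the aromatic carbon, and in this assay compound 2 gives 89600 nM. Among the measured compounds shown here, the step of an at least 11-fold lower number from compound 1 to compound 2 (1.04 log units; beyond the scatter) is the only measured step; it rests on (the limit of > 1000000 nM in this assay, at which 1 of the 2 values shown sits), so its true size is not fixed. Compound 3 `CCOC(=O)C12C(=O)OCC=C1COC2c1ccccn1` differs from compound 1 as follows: pyridin-2-yl in place of 4-fluorophenyl on a saturated ring carbon. This exchanges the whole aryl rather than a substituent on it, so the step from compound 1 to compound 2 bears on it only loosely: it shows that a change at this aryl can move this assay by a large amount, but in which direction a pyridin-2-yl moves it is not shown. Compound 1 stands at a limit, and compound 3 is expected to sit near it, estimated at 700000 nM with a range from 150000 nM to 3000000 nM. That estimate means an at least 1.4-fold lower number from compound 1 to compound 3 (0.15 log units; that floor lies within the scatter), and compound 3 is expected to report a limit more often than a number.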

Compound 3, half-maximal inhibitory concentration: > 1000000 nM
Compound 3 ended at the assay's limit; the forecaster's own chance of this, stated with the estimate: 60%; middle value at least 1.4-fold (0.15 log units) away from the limit.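

In this assay compound 3 gives > 1000000 nM, which is a limit of the assay and not a number. No step from compound 1 to compound 3 can be read, because both compounds sit at the same limit: the limit of > 1000000 nM in this assay, at which 2 of the 3 values shown sit.

Going by these compounds, whether pyridin-2-yl and 4-fluorophenyl differ at all in this assay stays open.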